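Benzyloxy in place of butoxy in a quinoline series

A few compounds are considered here, and "the series" means these few. Any claim that something is new, unique, unknown or untested is made for them only; others in the source may bear on it.

Of the compounds shown here, three of one shared core have been measured in a functional assay on KB cells (Homo sapiens) for cytotoxicity; a higher number here means that more compound is needed for the effect, a lower number that less compound is needed. Compound 3 `CCCCOc1cc(-c2ccccc2)nc2ccccc12` gives 3.8 ug/mL and stands highest of the two numbers that were obtained. Compound 2 `Oc1cc(-c2ccccc2)nc2c(F)cccc12` gives 0.53 ug/mL in this assay, a value set apart from that of compound 3 by a gap beyond the usual scatter. Compound 1 `Oc1cc(-c2ccccc2)nc2c(O)cccc12` reaches only a limit of this assay, > 10 ug/mL. That limit is the one described as the limit of > 10 ug/mL in this assay, at which 1 of the 3 values shown sits. Among the measured compounds shown here, the single step that can be read between measured compounds is an at least 18-fold lower number from compound 1 to compound 2 (1.27 log units; beyond the scatter), a fluoro in place of hydroxy on an aromatic carbon.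

Compound 4 `c1ccc(COc2cc(-c3ccccc3)nc3ccccc23)cc1` differs from compound 3 as follows: phenyl in place of propyl on a saturated chain carbon bound to an oxygen on an aromatic ring. For the measured compounds named here, the only measured step concerns a substituent on an aromatic carbon of the core and says nothing about the group on the saturated chain carbon bound to the oxygen on the aromatic ring. Going by the values given here, no measured step therefore bears on this change, and no direction can be drawn from the data; a step within the scatter is the expectation. On that basis compound 4 is expected to give about 4 ug/mL in this assay, in the range 1.5 ug/mL to 10 ug/mL, meaning an estimated step of a 1.1-fold higher number from compound 3 to compound 4 (0.02 log units; within the scatter).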

Compound 4, half-maximal effective concentration: 1.6 ug/mL
Estimate against measurement, compound 4: 2.5-fold (0.40 log units) above; the range from low to high includes it.
By their numbers in this assay, from the lowest: compound 2; then compound 4; then compound 3. At a limit, above all of these: compound 1.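

In this assay, among the compounds shown here, the group on the saturated chain carbon bound to an oxygen on an aromatic ring turns out to count: going from butoxy to benzyloxy gives a 2.4-fold lower number from compound 3 to compound 4 (0.38 log units; beyond the scatter), a first reading at this position, as the only earlier step lay on an aromatic carbon of the core. The step is modest, but it shows that phenyl in place of propyl at this place goes with less compound needed for the effect, not more, so a six-membered aromatic ring of carbon only is tolerated here without loss. Nothing among the measurements at hand speaks to why the number falls with this change.

The compounds shown leave open whether a longer chain such as hexyloxy, or a benzyloxy carrying an amine or a carboxylic acid on its phenyl, would lower the number further or raise it again. They also leave open whether the change from butoxy to benzyloxy would do the same on a core with fluoro on an aromatic carbon.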